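This account rests on a few compounds, and the source may have more. Where it says the series, first, only, none or still open, it means among the compounds named here.

Working notes on the series. The shared core appears in compound 1 `COc1cc(Cc2cnc(/N=C3\C(=O)N(CN4CCN(Cc5ccccc5)CC4)c4ccc(Cl)cc43)nc2N)cc(OC)c1OC`, compound 2 `CCn1cc(C(=O)O)c(=O)c2cc(F)c(N3CCN(CN4C(=O)/C(=N\c5ncc(Cc6cc(OC)c(OC)c(OC)c6)c(N)n5)c5cc(Cl)ccc54)C(C)C3)c(F)c21` and compound 3 `COc1cc(Cc2cnc(/N=C3\C(=O)N(CN4CCN(c5ccccn5)CC4)c4ccc(Cl)cc43)nc2N)cc(OC)c1OC`, all three read in an ADME assay on CCRF-CEM cells (Homo sapiens) for cytotoxicity, read by MTT assay, with a stated time of 5 days; a higher number here means that more compound is tolerated, a lower number that less compound is tolerated. In this assay compound 1 gives 94.7 ug/mL, compound 2 gives 18.7 ug/mL and compound 3 gives 29.4 ug/mL. Compound 3 therefore stands second highest of the three: its gap to compound 2 lies within the scatter, its gap to compound 1 beyond it. Going by the values given here, the only single-point step measured so far is a 3.2-fold lower number from compound 1 to compound 3 (0.51 log units; beyond the scatter).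

Compound 4 `COc1cc(Cc2cnc(/N=C3\C(=O)N(CN4CCN(C)CC4)c4ccc(Cl)cc43)nc2N)cc(OC)c1OC` has not been measured in this assay. It differs from compound 3 as follows: methyl in place of pyridin-2-yl on an amine nitrogen in a ring. Among the compounds with values here, no measured step exchanges a group on this amine nitrogen for methyl, so no direct precedent exists for direction. Within the data shown here, the one step at this place, a 3.2-fold lower number from compound 1 to compound 3 (0.51 log units; beyond the scatter), shows that changing the group on this nitrogen can move the number beyond the scatter, but it does not say which way methyl will go. The estimate is therefore centred near compound 3 with a wide range.

For compound 4 a value of 35 ug/mL is expected, ranging from 12 ug/mL to 110 ug/mL. The step this implies, a 1.2-fold higher number from compound 3 to compound 4 (0.08 log units; within the scatter), is expected to stay within the scatter.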

Compound 4, half-maximal cytotoxic concentration: 88 ug/mL
The estimate for compound 4 lay 2.5-fold (0.40 log units) below the measured number; the measured number falls inside the stated range.
By their numbers in this assay, from the lowest: compounds 2 and 3 (each within the scatter of the next); then compounds 4 and 1 (each within the scatter of the next).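

In this assay, a 3.0-fold higher number from compound 3 to compound 4 (0.48 log units; beyond the scatter), while a 1.1-fold lower number from compound 1 to compound 4 (0.03 log units; within the scatter). Methyl and benzyl on this amine nitrogen therefore read alike, and the phenyl of benzyl is not needed for the higher number. Among the three groups compared here, pyridin-2-yl alone stands apart, with the lower number, so the number does not simply follow the heavy-atom count of the group. Nothing at hand explains why pyridin-2-yl differs from methyl and benzyl.

Still open, on these data alone, is whether the lower number goes with the ring nitrogen of pyridin-2-yl or with any aromatic ring bound to this amine nitrogen, a question that a phenyl group there would help to settle. Also open, as far as these compounds go, is how a longer chain, such as propyl, or a hydroxyethyl group would read at this nitrogen.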